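This account rests on a few compounds, and the source may have more. Where it says the series, first, only, none or still open, it means among the compounds named here.

Two measured members of the series share one core with a fused bicyclic unit, differing only in that unit. Compound 1 `CCc1c(C)sc2nc(C(C)C)c(/C=C/[C@@H](O)C[C@@H](O)CC(=O)O)c(-c3ccc(F)cc3)c12` and compound 2 `Cc1nn(C)c2nc(C(C)C)c(/C=C/[C@@H](O)C[C@@H](O)CC(=O)O)c(-c3ccc(F)cc3)c12` were run in an in vivo functional assay on the whole organism for inhibition of 3-hydroxy-3-methylglutaryl-coenzyme A reductase (Rattus norvegicus), at a dose of 2 mg/kg by the oral route; on this read-out lower numbers stand for a weaker effect and higher numbers for a stronger effect at the one dose given. Compound 1 gives 20.8% in this assay. Among the measured compounds shown here, compound 2 gives 48.1% in this assay, the higher of the two numbers, and its gap to compound 1 lies beyond the scatter; no single-point step connects the pair, so only the two values can be read.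

Compound 3 `Cc1nn(-c2ccccc2)c2nc(C(C)C)c(/C=C/[C@@H](O)C[C@@H](O)CC(=O)O)c(-c3ccc(F)cc3)c12` has not yet been run in this assay. It stands next to compound 2 by one change: phenyl in place of methyl on an aromatic nitrogen on the fused two-ring system, two ring bonds from the ring atom that bears a methyl group.

For the measured compounds named here, no pair in the set differs in this one place, so the size of the step is open. Phenyl in place of methyl on an aromatic nitrogen is expected to leave inhibition near that of compound 2, with any step no larger than the scatter in either direction. Compound 3 is estimated at 52% in this assay, between 28% and 74%, which would mean an expected step of a number 3.9 percentage points higher from compound 2 to compound 3 (within the scatter).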

Compound 3, a percentage reported as inhibition, in the whole organism at one dose (the size of the read-out at that dose, not a potency): 19.9%
Compound 3: the middle estimate sits 32.1 percentage points above what was measured; the whole stated range lies above it.
By their numbers in this assay, from the lowest: compounds 3 and 1 (each within the scatter of the next); then compound 2.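

In this assay, phenyl in place of methyl on an aromatic nitrogen of the five-membered aromatic ring with 2 nitrogen gives a number 28.2 percentage points lower from compound 2 to compound 3 (beyond the scatter), the first step read at this position, and it shows that the group on this nitrogen can change the read-out and that phenyl gives up much of the effect seen with methyl. Since the read-out is a whole-organism effect at one dose, this step gives the size of the effect at that dose and not a shift in potency, and it cannot say whether the change acts on the enzyme or elsewhere in the animal. Nothing at hand accounts for the step.

From the compounds shown here alone, with only methyl and phenyl seen on this nitrogen, it remains open whether the read-out follows the number of heavy atoms in the group or the presence of the aromatic ring, which an ethyl group, a longer alkyl chain, a cyclohexyl ring or a benzyl group on the same nitrogen could help to separate. Also open, going by these compounds, is how a phenyl ring carrying fluorine, an amine or a carboxylic acid would read at this position.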